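This account rests on a few compounds, and the source may have more. Where it says the series, first, only, none or still open, it means among the compounds named here.

Measured compounds:

- compound 1, `Nc1ccccc1NC(=O)/C=C/c1ccc(CSc2ccc(Cl)cc2)cc1`: 3.27%
- compound 2, `Nc1ccccc1NC(=O)c1ccc(CSc2cccc(F)c2)cc1`: 81.4%

In a functional assay on HCT-116 cells (Homo sapiens) for inhibition, read by CCK-8 assay, with a stated time of 72 h, tested at 8 uM (a higher number here means more inhibition of growth at the concentration tested, a lower number less inhibition of growth), compound 1 gives 3.27%, the lower of the two values seen so far. Compound 2 differs from compound 1 in more than one place. In this assay, within the data shown here, compound 2 gives 81.4%, and no single step connects the two compounds, so the gap between them cannot be tied to either change alone.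

Compound 3, `Nc1ccccc1NC(=O)/C=C/c1ccc(CSc2ccc(C(F)(F)F)cn2)cc1`, is compound 1 with one group exchanged: 5-(trifluoromethyl)pyridin-2-yl in place of 4-chlorophenyl on a sulfur. Among the measured compounds shown here, no measured pair shows the effect of such an exchange on the sulfur, so the direction of the step in this assay is open. The expectation for compound 3 is a modest upward step, a number 16.7 percentage points higher from compound 1 to compound 3 (beyond the scatter), possibly within the scatter. Compound 3 is therefore estimated at 20% in this assay, with a range from 0% to 55%, the wide range reflecting the absence of any measured step for this change.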

Compound 3, percent growth inhibition at one concentration: 14.9%
Estimate against measurement, compound 3: 5.1 percentage points above; measured number inside the range.
By their numbers in this assay, from the lowest: compound 1; then compound 3; then compound 2.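

In this assay, among these compounds, the first readable exchange on the sulfur, 5-(trifluoromethyl)pyridin-2-yl in place of 4-chlorophenyl, gives a number 11.6 percentage points higher from compound 1 to compound 3 (beyond the scatter). The sulfur substituent can therefore shift the read-out beyond the scatter with the rest of compound 1 unchanged, although compound 3 still gives only 14.9%, so this exchange alone does not produce strong growth inhibition. No measured evidence bears on why the step occurs.

The compounds shown do not separate the contribution of the ring nitrogen from that of the trifluoromethyl group; a plain pyridin-2-yl or a phenyl carrying trifluoromethyl on the sulfur would address this. How an amine or a carboxylic acid on that ring would behave also remains open, as does which of the several differences in compound 2 accounts for its much higher value.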